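A few compounds are considered here, and "the series" means these few. Any claim that something is new, unique, unknown or untested is made for them only; others in the source may bear on it.

In a functional assay on 518A2 cells (Homo sapiens) for cytotoxicity, read by sulforhodamine B assay, with a stated time of 96 h (a higher number here means that more compound is needed for the effect, a lower number that less compound is needed), three compounds on the shared core have been measured: compound 1 (`CCCC(=O)CC/C=C/C=C/C#CC#C/C=C/COC(C)=O`) gives 9100 nM, compound 2 (`CCCC(=O)CC/C=C/C=C/C#CC#C/C=C/COC(=O)c1ccccc1`) gives 20500 nM and compound 3 (`CCCC(=O)CC/C=C/C=C/C#CC#C/C=C/COC(=O)CCl`) gives 12600 nM. That last value lies within the scatter of the other two: a 1.4-fold higher number from compound 1 to compound 3 (0.14 log units; within the scatter) and a 1.6-fold lower number from compound 2 to compound 3 (0.21 log units; within the scatter). Only a 2.3-fold higher number from compound 1 to compound 2 (0.35 log units; beyond the scatter) goes beyond the scatter, and modestly. Compound 4 (`CCCC(=O)CC/C=C/C=C/C#CC#C/C=C/C=O`) brings formyl in place of (((chloromethyl)carbonyl)oxy)methyl on a double-bonded chain carbon bound to a double-bonded chain carbon. Among the compounds with values here, no measured step covers this change, since all three vary only the group on a carbonyl carbon. In this assay, within the data shown here, no step clearly beyond the scatter is expected, with a weak lean toward a lower number. The expected step is a 1.6-fold lower number from compound 3 to compound 4 (0.20 log units; within the scatter). The estimate for compound 4 is 8000 nM, with an expected range of 2500 nM to 25000 nM.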

Compound 4, half-maximal effective concentration: > 30000 nM
Compound 4 was reported as a limit; the forecaster's own chance of this, stated with the estimate: 5%; at least 3.7-fold (0.57 log units) between middle value and limit.
By their numbers in this assay, from the lowest: compounds 1, 3 and 2 (each within the scatter of the next, the first and the last beyond it). At a limit, above all of these: compound 4.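

Formyl in place of (((chloromethyl)carbonyl)oxy)methyl gives an at least 2.3-fold higher number from compound 3 to compound 4 (0.37 log units; beyond the scatter), and formyl in place of acetoxymethyl gives an at least 3.2-fold higher number from compound 1 to compound 4 (0.51 log units; beyond the scatter). Within the data shown here, both steps lie beyond the scatter, whereas the earlier changes, confined to the group on a carbonyl carbon, produced only one such step, a modest one. In this assay compound 4 is reported only as a limit: the limit of > 30000 nM in this assay, at which 1 of the 4 values shown sits.

On these data alone, the full size of both steps therefore stays open. As far as these compounds go, it also stays open whether a hydroxymethyl group, a carboxylic acid or an amide on this double-bonded chain carbon would track the esters or formyl.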